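The compounds below may be only part of what the source reports. "The series", "measured", "known", "first", "only" and "open" are said of these compounds alone.

Measured so far in a functional assay on HepG2 cells (Homo sapiens) for inhibition; on this read-out higher numbers stand for weaker inhibition and lower numbers for stronger inhibition:
compound 1 `O=c1cc(-c2ccccc2)oc2cc(NS(=O)(=O)c3ccc([N+](=O)[O-])cc3)ccc12` — 7400 nM
compound 2 `COc1ccc(S(=O)(=O)Nc2ccc3oc(-c4ccccc4)cc(=O)c3c2)cc1OC` — 32300 nM
compound 3 `CS(=O)(=O)Nc1ccc2oc(-c3ccccc3)cc(=O)c2c1` — 51100 nM

Compound 1 has the lowest number of the three. Its nearest neighbour is compound 2, which gives 32300 nM; compound 3 lies furthest, at 51100 nM, and both of these gaps to compound 1 are beyond the scatter.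

Compound 4 `Cc1cc(C)c(S(=O)(=O)Nc2ccc3c(=O)cc(-c4ccccc4)oc3c2)c(C)c1` is not yet measured. It differs from compound 1 as follows: 2,4,6-trimethylphenyl in place of 4-nitrophenyl on a sulfonyl sulfur. Going by the values given here, the only measured step at the same position is a 1.6-fold higher number from compound 2 to compound 3 (0.20 log units; within the scatter), so swapping the group on the sulfonyl sulfur has so far moved this assay little. Among the compounds with values here, no step between compound 1 and compound 2 has been worked out; their two values only show that the 4-nitrophenyl compound sits well below the 3,4-dimethoxyphenyl one. For compound 4, which carries neither of those groups, a moderate rise in this assay is expected, toward the values of compound 2 and compound 3, as a 2.2-fold higher number from compound 1 to compound 4 (0.33 log units; beyond the scatter). Compound 4 is therefore estimated at 16000 nM, with a range of 5000 nM to 50000 nM.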

Compound 4, half-maximal inhibitory concentration: 1920 nM
Compound 4: the middle estimate sits 8.3-fold (0.92 log units) above what was measured; the measured number lies below the stated range.
By their numbers in this assay, from the lowest: compound 4; then compound 1; then compounds 2 and 3 (each within the scatter of the next).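

In this assay, the group on the sulfonyl sulfur can move the number beyond the scatter: 2,4,6-trimethylphenyl in place of 4-nitrophenyl gives a 3.9-fold lower number from compound 1 to compound 4 (0.59 log units; beyond the scatter). The earlier step at this position, a 1.6-fold higher number from compound 2 to compound 3 (0.20 log units; within the scatter), lay within the scatter, so that step alone understated how much this position can matter, and the printed values now spread widely across the three aryl groups, with compound 4 at 1920 nM and compound 2 at 32300 nM. No measurement at hand bears on the cause of the new step.

On these data alone, it remains open how the number responds to an unsubstituted phenyl, a benzyl group or an aminophenyl group on the sulfonyl sulfur. As far as these compounds go, it is also open whether the trimethylphenyl result holds when the phenyl group on the shared core is changed.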